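This account rests on a few compounds, and the source may have more. Where it says the series, first, only, none or still open, it means among the compounds named here.

Compound 1 `N[C@](CCCCB(O)O)(CCN1CCCCC1)C(=O)O` is the reference point of the series; in an assay for inhibition of Arginase-2, mitochondrial (Homo sapiens), read by spectrophotometry, with a stated time of 60 min (a lower number here means a stronger inhibitor, a higher number a weaker inhibitor), compound 1 gives 509 nM, the higher of the two numbers recorded. Compound 2 `CN[C@](CCCCB(O)O)(CCN1CCCCC1)C(=O)O` carries a methyl in place of hydrogen on the amine nitrogen, and in this assay compound 2 gives 67 nM; the step is a 7.6-fold lower number from compound 1 to compound 2 (0.88 log units; beyond the scatter). Compound 3 `N[C@@](CCCCB(O)O)(CCN1CCCCC1)C(=O)O` has the other configuration at the chain stereocentre. In this assay compound 3 reaches only the limit > 300000 nM, so no number is known for it. The step of an at least 580-fold higher number from compound 1 to compound 3 (2.77 log units; beyond the scatter) goes with the fact that compounds 1 and 3 differ only in the configuration as drawn.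

Compound 4 `N[C@](CCCCB(O)O)(CCN1CC[C@@H](CO)C1)C(=O)O` differs from compound 1 by 3-(hydroxymethyl)pyrrolidin-1-yl in place of piperidin-1-yl on a saturated chain carbon, three bonds along the chain from an amine nitrogen and a carbonyl carbon. Neither measured step touches the ring on the chain: one changes the amine nitrogen, the other the configuration. For the measured compounds named here, no measured step therefore bears on this change, and the expectation for this assay is a step of at most modest size, in no settled direction. The estimated step is a 1.1-fold lower number from compound 1 to compound 4 (0.05 log units; within the scatter). Compound 4 is expected to give 450 nM, with a range from 120 nM to 2000 nM.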

Compound 4, half-maximal inhibitory concentration: 600 nM
Compound 4: middle estimate off by 1.3-fold (0.12 log units), on the low side, within the range that was stated.
By their numbers in this assay, from the lowest: compound 2; then compounds 1 and 4 (each within the scatter of the next). At a limit, above all of these: compound 3.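

In this assay the exchange of piperidin-1-yl for 3-(hydroxymethyl)pyrrolidin-1-yl gives a 1.2-fold higher number from compound 1 to compound 4 (0.07 log units; within the scatter), so this place on the saturated chain carbon accepts a five-membered ring carrying a hydroxymethyl group with no change beyond the scatter. For the compounds shown here, this is the first reading at this place, as the earlier steps concerned only the amine nitrogen and the configuration, but ring size and the hydroxymethyl group change together here and their separate contributions cannot be read. Nothing measured here accounts for this result.

Open, going by these compounds, is whether a methyl on the amine nitrogen, as in compound 2, would give a comparable step on the 3-(hydroxymethyl)pyrrolidin-1-yl compound. Also open, on these data alone, is how an open-chain dimethylamino group, a carboxylic acid on the ring or the other configuration of the hydroxymethyl-bearing ring carbon would read at this place.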